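A Methyl Added to a Sulfonamide Chain, Seen Twice

This account rests on a few compounds, and the source may have more. Where it says the series, first, only, none or still open, it means among the compounds named here.

Of the compounds shown here, three have been measured, and a fourth shares the same small change with one measured pair. Compound 1 `COc1cc(NC(=O)c2ccc(Cl)c([N+](=O)[O-])c2)ccc1NS(C)(=O)=O` and compound 2 `CCS(=O)(=O)Nc1ccc(NC(=O)c2ccc(Cl)c([N+](=O)[O-])c2)cc1OC` are built on one core, while compound 3 `CS(=O)(=O)Nc1ccc(NC(=O)c2ccc(Cl)cc2)cc1F` and compound 4 `CCS(=O)(=O)Nc1ccc(NC(=O)c2ccc(Cl)cc2)cc1F` are built on another; the difference between the two cores is not broken down here.

In an ADME assay on RAW264.7 cells (Mus musculus) for cytotoxicity, read by MTT assay, with a stated time of 48 h (on this read-out higher numbers stand for weaker inhibition and lower numbers for stronger inhibition), compound 1 reaches only a limit of the assay, > 250000 nM, which is a bound and not a number. In this assay compound 2 gives 5660 nM. The change between them is methyl in place of hydrogen on a saturated chain carbon bound to a sulfonyl sulfur, and it made a step of an at least 44-fold lower number from compound 1 to compound 2 (1.64 log units; beyond the scatter). The size of that step rests partly on (the limit of > 250000 nM in this assay, at which 1 of the 3 values shown sits), so its true size is not pinned down beyond being at least that large.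

In this assay compound 3 gives 22300 nM, the highest of the two numbers shown. Among the measured compounds shown here, the change from compound 3 to compound 4 is methyl in place of hydrogen on a saturated chain carbon bound to a sulfonyl sulfur, the same change in the same place as the one from compound 1 to compound 2, only on a different core.

On that basis the step is expected to run in the same direction, but with caution, since it is carried over from one pair onto a different core: the expected step is a 7.4-fold lower number from compound 3 to compound 4 (0.87 log units; beyond the scatter). For compound 4 the estimated value in this assay is 3000 nM, expected to fall between 400 nM and 15000 nM.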

Compound 4, half-maximal inhibitory concentration: 152000 nM
Estimate against measurement, compound 4: 51-fold (1.70 log units) below; measured number outside the range, above it.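

On the second core, methyl in place of hydrogen on a saturated chain carbon bound to a sulfonyl sulfur gives a 6.8-fold higher number from compound 3 to compound 4 (0.83 log units; beyond the scatter) in this assay, so the number rises where it fell on the first core. The change from methylsulfonyl to ethylsulfonyl therefore does not carry from one core to the other in these compounds, and its direction on one core gives no safe guide to its direction on the other: the same change on two cores in this assay, an at least 44-fold lower number (1.64 log units; beyond the scatter) from compound 1 to compound 2 and a 6.8-fold higher number (0.83 log units; beyond the scatter) from compound 3 to compound 4, at least 300-fold (2.47 log units) apart, beyond the scatter of two such steps

This rests on only two pairs, and they do not show which difference between the cores turns the step around; compound 1 also stands at a limit and not a number, so the earlier step has a direction but no exact size: the limit of > 250000 nM in this assay, at which 1 of the 4 values shown sits.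

From the compounds shown here alone, it remains open whether a longer chain on the sulfonyl sulfur, such as propyl, would continue the direction seen on each core, or whether the two cores would keep moving apart. Also open, going by these compounds, is which part of the cores matters, and a series of compounds that changes them one place at a time, with both the methylsulfonyl and ethylsulfonyl forms, could begin to answer that.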